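A few compounds are considered here, and "the series" means these few. Any claim that something is new, unique, unknown or untested is made for them only; others in the source may bear on it.

Working notes on the series

Measured so far:
- compound 1 (`O=C(Nc1ccccc1)Nc1cccc(Nc2ncc(Cl)c(Nc3ccc4cn[nH]c4c3)n2)c1`) at 3500 nM 
- compound 2 (`O=C(Nc1ccccc1)Nc1cccc(Nc2nccc(Nc3ccc4[nH]ncc4c3)n2)c1`) at 8100 nM 

In a functional assay on HepG2 cells (Homo sapiens) for inhibition, read by fluorescence and resazurin assay, with a stated time of 72 h (a lower number here means a stronger inhibitor, a higher number a weaker inhibitor), compound 2 holds the higher of the two numbers, at 8100 nM against compound 1 at 3500 nM with a gap beyond the scatter. These two compounds differ in more than one place, so the series does not yet contain a measured step for any single structural change.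

The next compound is compound 3 (`Cc1c2ccc(Nc3ccnc(Nc4cccc(NC(=O)Nc5ccccc5)c4)n3)cc2nn1C`), which carries 2,3-dimethyl-2H-indazol-6-yl in place of 1H-indazol-5-yl on a nitrogen on an aromatic ring. Among the measured compounds shown here, no measured pair shows what this exchange does, so the direction cannot be called with confidence. A step in this assay no larger than the scatter is the working expectation, resting only on compound 1 and compound 2 and their values above. An estimated 1.2-fold lower number from compound 2 to compound 3 (0.06 log units; within the scatter) is expected on that basis. For compound 3 the expected value is 7000 nM within an estimated range of 2500 nM to 20000 nM in the same read-out.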

Compound 3, half-maximal inhibitory concentration: 2400 nM
The estimate for compound 3 lay 2.9-fold (0.46 log units) above the measured number, outside the stated range (below it).
By their numbers in this assay, from the lowest: compounds 3 and 1 (each within the scatter of the next); then compound 2.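

In this assay, among the compounds shown here, the exchange of 1H-indazol-5-yl for 2,3-dimethyl-2H-indazol-6-yl on a nitrogen on an aromatic ring gives a 3.4-fold lower number from compound 2 to compound 3 (0.53 log units; beyond the scatter) and is the first single-place step measured. The step shows that this position accepts a change of both the attachment point on the indazole and its substitution, and that the number still falls when the entering group has no hydrogen-bond donor, so the donor counted on 1H-indazol-5-yl is not required for inhibition at this level in this read-out. No measurement here accounts for the size or direction of this step.

The exchange alters the attachment point, the two methyl groups and the hydrogen-bond donor count together, so the compounds shown do not separate the part each plays, and compound 1 differs from compound 3 in more than one place, so no step links them. Also open, from the compounds shown here alone, is how far the position tolerates a group outside the indazoles, such as a plain phenyl or a pyridine carrying an amine.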